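Cytotoxicity notes: from compound 3 to compound 4

The compounds below may be only part of what the source reports. "The series", "measured", "known", "first", "only" and "open" are said of these compounds alone.

In a toxicity assay on MDCK cells (Canis lupus familiaris) for cytotoxicity, read by crystal violet staining, with a stated time of 48 h (a lower number here means that less compound is tolerated, a higher number that more compound is tolerated), compound 1 `Cc1ccc2cc(CN(Cc3ccc(F)cc3)Cc3ccc(C(C)(C)C)cc3)c(=O)[nH]c2c1` gives only a limit, > 33000 nM. Compound 2 `Cc1ccc2[nH]c(=O)c(CN(Cc3ccc(C(C)(C)C)cc3)[C@H](CO)c3ccccc3)cc2c1` likewise sits at a limit in this assay, > 10000 nM. Compound 3 `CCc1ccc2[nH]c(=O)c(CN(Cc3ccc(C(C)(C)C)cc3)[C@H](CO)c3ccccc3)cc2c1` also returns only a limit in this assay, > 10000 nM. The step that the two limits leave unreadable from compound 2 to compound 3 is accordingly not readable. Compound 3 stands where two of the three values stand, at a limit; none of the three values is a number, as the limit of > 10000 nM in this assay, at which 2 of the 3 values shown sit, and the limit of > 33000 nM in this assay, at which 1 of the 3 values shown sits, record.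

Compound 4 `CCc1ccc2[nH]c(=O)c(CN(Cc3ccc(C(C)(C)C)cc3)C(C)c3ccc(OC(F)F)cc3)cc2c1` differs from compound 3 by 1-(4-(difluoromethoxy)phenyl)ethyl in place of 2-hydroxy-1-phenylethyl on an amine nitrogen. For the measured compounds named here, no measured step bears on this change at this place, and the single measured step, a step that the two limits leave unreadable from compound 2 to compound 3, concerns another place and cannot be read. With every value in the set at a limit, the step that the limit leaves unreadable from compound 3 to compound 4 is expected to stay within the scatter. Compound 4 is therefore estimated at 20000 nM, in a range from 7000 nM to 60000 nM, most likely again reported only as a limit.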

Compound 4, half-maximal cytotoxic concentration: > 5000 nM
Compound 4 gave a limit, no number (the forecaster's own chance of this, stated with the estimate: 70%); the middle value is on the limit's open side.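

Compound 3 and compound 4 both return only limits in this assay, so the step between them cannot be read. The compounds shown leave open whether 1-(4-(difluoromethoxy)phenyl)ethyl in place of 2-hydroxy-1-phenylethyl on an amine nitrogen changes the half-maximal cytotoxic concentration at all.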